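The source may hold more compounds than are shown below. What is called first, only, known or untested is meant among the compounds shown, and "the series" means these compounds.

The measured compounds are few. Compound 1, `O=C(Nc1cccc(-c2oc3cc(-c4ccc(F)cc4)ccc3c(=O)c2O)c1)c1ccc(F)cc1F`, gives 11200 nM in a functional assay on MDA-MB-231 cells (Homo sapiens) for antiproliferative activity, read by CCK-8 assay, with a stated time of 72 h; on this read-out higher numbers stand for weaker inhibition and lower numbers for stronger inhibition. Compound 2, `O=C(Nc1cccc(-c2oc3cc(-c4ccc(F)cc4)ccc3c(=O)c2O)c1)c1ccc(Br)cc1`, gives 24900 nM. Compound 3, `Cc1cccc(C(=O)Nc2cccc(-c3oc4cc(-c5ccc(F)cc5)ccc4c(=O)c3O)c2)c1`, gives 2840 nM.

Compound 3 stands lowest of the three: the steps of a 3.9-fold lower number from compound 1 to compound 3 (0.60 log units; beyond the scatter) and an 8.8-fold lower number from compound 2 to compound 3 (0.94 log units; beyond the scatter) both lie beyond the scatter, and the step of a 2.2-fold higher number from compound 1 to compound 2 (0.35 log units; beyond the scatter) separates the other two. Every difference among these compounds sits on the same carbonyl carbon of the amide, so all three steps bear on the next change, though none of them repeats it exactly.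

Compound 4, `COc1cc(OC)cc(C(=O)Nc2cccc(-c3oc4cc(-c5ccc(F)cc5)ccc4c(=O)c3O)c2)c1`, differs from compound 3 by 3,5-dimethoxyphenyl in place of 3-methylphenyl on a carbonyl carbon. The three measured steps show that exchanging the aryl group on this carbonyl carbon moves the number by modest amounts in either direction, with compound 3 at the favourable end. Without a closer precedent, a small step towards a higher number is expected, a 1.6-fold higher number from compound 3 to compound 4 (0.20 log units; within the scatter), and compound 4 is estimated at 4500 nM, with a range from 1500 nM to 15000 nM.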

Compound 4, half-maximal inhibitory concentration: 4040 nM
Beside the measured number, compound 4's estimate is 1.1-fold (0.05 log units) above it; low and high end bracket the measured number.
By their numbers in this assay, from the lowest: compounds 3 and 4 (each within the scatter of the next); then compound 1; then compound 2.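

On this carbonyl carbon, 3,5-dimethoxyphenyl and 3-methylphenyl cannot be told apart in this assay (a 1.4-fold higher number from compound 3 to compound 4 (0.15 log units; within the scatter)), so the aryl group here can carry methoxy groups without a change beyond the scatter. The other two steps (a 2.8-fold lower number from compound 1 to compound 4 (0.44 log units; beyond the scatter)) and (a 6.2-fold lower number from compound 2 to compound 4 (0.79 log units; beyond the scatter)) lie beyond the scatter and, among these four compounds, place both halogen-bearing aryl groups at higher numbers than both aryl groups without halogen, with no compound going against this. Nothing shown gives a reason for this ordering.

On these data alone, whether a morpholine ring or a carboxylic acid on this aryl group would move the number stays open. As far as these compounds go, all four compounds also share the 4-fluorophenyl group on the core, so what happens when that group is exchanged, for example for a plain phenyl, remains unknown.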